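The compounds below may be only part of what the source reports. "The series", "measured", "known", "first", "only" and "open" are said of these compounds alone.

Compound 1 `N#C[C@H]1C[C@@H]1CN([C@H](CCC(F)(F)F)C(N)=O)S(=O)(=O)c1ccc(Cl)cc1`: 21.5 10^-6 cm/s
Compound 2 `C[C@]1(C#N)C[C@H](CN([C@H](CCC(F)(F)F)C(N)=O)S(=O)(=O)c2ccc(Cl)cc2)C1`: 21.8 10^-6 cm/s
Compound 3 `C[C@]1(C#N)C[C@@H](CN([C@H](CCC(F)(F)F)C(N)=O)S(=O)(=O)c2ccc(Cl)cc2)C1`: 25.7 10^-6 cm/s

In an ADME assay on MDCKII-LE cells (Canis lupus familiaris) for permeability (on this read-out lower numbers stand for lower permeability and higher numbers for higher permeability), compound 3 gives 25.7 10^-6 cm/s, level with the other two: a 1.2-fold higher number from compound 1 to compound 3 (0.08 log units; within the scatter) and a 1.2-fold higher number from compound 2 to compound 3 (0.07 log units; within the scatter). Compound 4 `NC(=O)[C@@H](CCC(F)(F)F)N(CCCc1ncon1)S(=O)(=O)c1ccc(Cl)cc1` carries 2-(1,2,4-oxadiazol-3-yl)ethyl in place of 3-cyano-3-methylcyclobutyl on a saturated chain carbon bound to a sulfonamide nitrogen. The nearest measured change at this place is a 1.0-fold higher number from compound 1 to compound 2 (0.01 log units; within the scatter), a swap between two cyano-bearing rings. Among the compounds with values here, no measured compound carries the oxadiazole, so this guide is loose and the range is kept wide. No step beyond the scatter is expected, and the expected step is a 1.4-fold lower number from compound 3 to compound 4 (0.15 log units; within the scatter). For compound 4 the estimated value is 18 10^-6 cm/s, with an expected range from 8 10^-6 cm/s to 32 10^-6 cm/s.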

Compound 4, apparent permeability: 31.3 10^-6 cm/s
Beside the measured number, compound 4's estimate is 1.7-fold (0.24 log units) below it, within the range that was stated.
By their numbers in this assay, from the lowest: compounds 1, 2, 3 and 4 (each within the scatter of the next).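

In this assay the move to an open chain carrying an aromatic ring gives a 1.2-fold higher number from compound 3 to compound 4 (0.09 log units; within the scatter) and a 1.4-fold higher number from compound 2 to compound 4 (0.16 log units; within the scatter) and a 1.5-fold higher number from compound 1 to compound 4 (0.16 log units; within the scatter) as well, so a carbon ring bearing a nitrile is not required at this position for this read-out. The position on a saturated chain carbon bound to a sulfonamide nitrogen thus takes 3-(1,2,4-oxadiazol-3-yl)propyl without a step beyond the scatter. Nothing given here explains why the read-out holds across these groups. Going by these compounds, whether a carboxylic acid, an amine or a longer chain here would also stay within the scatter remains open.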